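The source may report more compounds than this note shows. Statements on the series, on what has been measured and on what is new or still open speak of the compounds shown alone.

Working notes on the series. In an ADME assay on PC-12 cells (Rattus norvegicus) for cytotoxicity, read by MTT assay, with a stated time of 24 h (a higher number here means that more compound is tolerated, a lower number that less compound is tolerated), compound 1 `Cc1c(C(=O)OCC#CCN2CCN(c3cc(C4CC4)ccc3C#N)CC2)sc2ncnc(N3CCCCC3)c12` gives 148 ug/mL and compound 2 `Cc1c(-c2nnc(-c3ccccc3)o2)sc2ncnc(N3CCCCC3)c12` gives 146 ug/mL. These two values lie within the scatter of each other, so compound 2 stands level with compound 1 on the numbers available, even though the two structures differ widely outside the shared core.

Compound 3 `Cc1ccc(-c2nnc(-c3sc4ncnc(N5CCCCC5)c4c3C)o2)cc1` departs from compound 2 by a single small change: methyl in place of hydrogen on an aromatic carbon. This is methyl in place of hydrogen on an aromatic carbon, para to a large group, or phenyl to 4-methylphenyl when cut one bond further out.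

Among the compounds with values here, the series offers no measured step between compounds that differ in one place, so nothing shows directly how this assay responds to such a change. Within the data shown here, with only this small change, no shift beyond the scatter is expected, and no direction can be favoured. The anchor is compound 2 at 146 ug/mL. The expected step is a 1.0-fold lower number from compound 2 to compound 3 (0.02 log units; within the scatter), which is estimated to stay within the scatter. For compound 3 the estimated value is 140 ug/mL, with an expected range of 75 ug/mL to 260 ug/mL.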

Compound 3, half-maximal cytotoxic concentration: 161 ug/mL
Compound 3: middle estimate off by 1.2-fold (0.06 log units), on the low side, within the range that was stated.
By their numbers in this assay, from the lowest: compounds 2, 1 and 3 (each within the scatter of the next).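

In this assay, within the data shown here, the first step between compounds that differ in one place reads a 1.1-fold higher number from compound 2 to compound 3 (0.04 log units; within the scatter), which lies within the scatter. Methyl in place of hydrogen on an aromatic carbon of the six-membered aromatic ring of carbon only, para to a large group, therefore leaves compound 3 level with compound 2, and the change from phenyl to 4-methylphenyl is one that this assay does not separate at this position. No available information bears on why these two compounds read alike.

Going by these compounds, whether an amine, a carboxylic acid or a longer chain at the same place would also stay within the scatter remains open, as does the reading for methyl on another carbon of the same ring. Among these compounds, a single step with one small group also leaves open whether the same change would read alike on a different core, so this result describes only the pair of compound 2 and compound 3 and sets no general rule for the series.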